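Aldehyde in place of the nitrogen group, compound 3

The source may hold more compounds than are shown below. What is called first, only, known or untested is meant among the compounds shown, and "the series" means these compounds.

Measured so far in a functional assay on NALM-6 cells (Homo sapiens) for cytotoxicity, with a stated time of 72 h; on this read-out lower numbers stand for an effect already at smaller amounts and higher numbers for an effect only at larger amounts of compound:
- compound 1 `C=C[C@@](C)(/C=C/c1ccc(O)cc1)CC/C=C/C(=O)OCC`: > 43400 nM
- compound 2 `C=C[C@@](C)(/C=C/c1ccc(O)cc1)CC/C=C(C)/C=N/N`: > 43400 nM

Compound 1 is reported only as a limit. Compound 2 stands at > 43400 nM, which is likewise a limit and not a number. All the data in this small series therefore sit at one ceiling: the limit of > 43400 nM in this assay, at which 2 of the 2 values shown sit.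

The next structure is compound 3 `C=C[C@@](C)(/C=C/c1ccc(O)cc1)CC/C=C(\C)C=O`. Its difference from compound 2 is a group of 2 heavy atoms (1 carbon, 1 oxygen; no ring) in place of a group of 3 heavy atoms (1 carbon, 2 nitrogen; no ring), on a double-bonded chain carbon bound to a double-bonded chain carbon and a saturated chain carbon, with formyl entering on a double-bonded chain carbon bound to a double-bonded chain carbon and a saturated chain carbon.

Going by the values given here, only one measured step bears on this change: a step that the two limits leave unreadable from compound 1 to compound 2. Among the compounds with values here, that step has no readable size, so it offers neither a magnitude nor a direction to carry over, and no measured compound carries formyl. The expectation is therefore no readable change in this assay, with a report at the limit the likeliest outcome. The expected step is an at least 1.0-fold lower number from compound 2 to compound 3 (0.03 log units; that floor lies within the scatter), and this estimate is loose. For compound 3 the estimated value is 40000 nM, with an expected range of 15000 nM to 90000 nM.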

Compound 3, half-maximal effective concentration: 12600 nM
Compound 3: middle estimate off by 3.2-fold (0.50 log units), on the high side; measured number below the stated range.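

In this assay, going by these compounds alone, the exchange of the nitrogen group for formyl, on a double-bonded chain carbon bound to a double-bonded chain carbon and a saturated chain carbon, gives an at least 3.4-fold lower number from compound 2 to compound 3 (0.53 log units; beyond the scatter), the first readable step. Read against the ester-bearing compound, the replacement of 2-(ethoxycarbonyl)ethenyl by 2-formylprop-1-en-1-yl gives an at least 3.4-fold lower number from compound 1 to compound 3 (0.53 log units; beyond the scatter), so the formyl compound stands clear of both earlier structures, and both steps are floors rather than sizes. The step between compound 1 and compound 2 cannot be read, and the two earlier compounds remain at a limit of the assay, which is not a number: the limit of > 43400 nM in this assay, at which 2 of the 3 values shown sit.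

With only compound 3 carrying a number, the compounds shown do not separate a contribution of formyl itself from that of the rest of the 2-formylprop-1-en-1-yl chain end, nor do they give the true size of either step. Also open, as far as these compounds go, is how a carboxylic acid, a hydroxymethyl group or a primary amine in place of formyl, on the same double-bonded chain carbon, would read in this assay.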